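Replacing 4-fluorophenyl with piperidin-4-yl

A few compounds are considered here, and "the series" means these few. Any claim that something is new, unique, unknown or untested is made for them only; others in the source may bear on it.

- compound 1 `Cn1cc(-c2cnc3[nH]cc(-c4ccc(F)cc4)c3c2)cn1`: 9000 nM
- compound 2 `Cn1cc(-c2cnc3[nH]cc(-c4ccc(F)c(F)c4)c3c2)cn1`: 5000 nM
- compound 3 `Cn1cc(-c2cnc3[nH]cc(-c4ccc(C(N)=O)cc4)c3c2)cn1`: 3000 nM

These values come from a physicochemical assay for solubility, read by LC-MS, in phosphate buffer, measured as thermodynamic solubility, with a stated time of 24 h, at pH 7.4; a higher number here means a more soluble compound, a lower number a less soluble compound. Compound 1 and compound 2 sit together at the upper end of the three numbers, with a 1.8-fold lower number from compound 1 to compound 2 (0.26 log units; within the scatter). Compound 3 stands clearly apart, with a 3.0-fold lower number from compound 1 to compound 3 (0.48 log units; beyond the scatter).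

Compound 4 `Cn1cc(-c2cnc3[nH]cc(C4CCNCC4)c3c2)cn1` keeps the shared core but swaps a whole ring: piperidin-4-yl in place of 4-fluorophenyl on an aromatic carbon. Both measured steps only change a group on the aromatic ring that compound 4 loses, so they offer weak guidance. For the measured compounds named here, no measured compound carries a piperidin-4-yl group, so the size of the step is uncertain. A rise in this assay, larger than either measured step, is nevertheless expected. The estimated change is a 6.7-fold higher number from compound 1 to compound 4 (0.82 log units; beyond the scatter). Compound 4 is estimated at 60000 nM, with an expected range of 12000 nM to 300000 nM.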

Compound 4, solubility: 770000 nM
Compound 4: middle estimate off by 13-fold (1.11 log units), on the low side, outside the stated range (above it).
By their numbers in this assay, from the lowest: compounds 3, 2 and 1 (each within the scatter of the next, the first and the last beyond it); then compound 4.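

On the shared core, putting the non-aromatic piperidin-4-yl ring in place of the aromatic 4-fluorophenyl ring gives an 86-fold higher number from compound 1 to compound 4 (1.93 log units; beyond the scatter) in this assay and this step is far larger than either earlier step. Exchanging the whole ring at this position can therefore move the number much further than changing a group on the aromatic ring. No measurement shown here accounts for the size of this step. As far as these compounds go, what remains open is whether the ring nitrogen or the loss of the aromatic ring matters more. A cyclohexyl ring or a 1-methylpiperidin-4-yl group at the same position would help separate the two.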